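Methyl Removal on a Shared Core: Expected Cytotoxicity

The source may report more compounds than this note shows. Statements on the series, on what has been measured and on what is new or still open speak of the compounds shown alone.

Four compounds share one core and differ at two aromatic positions. In a functional assay on SK-OV-3 cells (Homo sapiens) for cytotoxicity, read by MTT assay, with a stated time of 48 h (on this read-out higher numbers stand for weaker inhibition and lower numbers for stronger inhibition), compound 1 `O=c1[nH]c2ccccc2cc1-c1nc2cc(F)ccc2[nH]1` gives 18300 nM. Compound 2 `Cc1ccc2[nH]c(=O)c(-c3nc4cc(F)ccc4[nH]3)cc2c1` reaches only the limit of this assay, > 100000 nM, which is a limit and not a number (the limit of > 100000 nM in this assay, at which 1 of the 3 values shown sits). Compound 3 `Cc1ccc2[nH]c(=O)c(-c3nc4cc(Cl)ccc4[nH]3)cc2c1` gives 33000 nM. Compound 4 `O=c1[nH]c2ccccc2cc1-c1nc2cc(Cl)ccc2[nH]1` has not yet been measured in this assay.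

From compound 2 to compound 3 the change is chloro in place of fluoro on an aromatic carbon, and it gives an at least 3.0-fold lower number from compound 2 to compound 3 (0.48 log units; beyond the scatter). From compound 2 to compound 1 the change is hydrogen in place of methyl on an aromatic carbon, and it gives an at least 5.4-fold lower number from compound 2 to compound 1 (0.73 log units; beyond the scatter). The values of compound 1 and compound 3 lie close to each other.

Compound 4 arises from compound 3 by hydrogen in place of methyl on an aromatic carbon, the same change as from compound 2 to compound 1, at the same kind of position. As far as these compounds go, the earlier step, an at least 5.4-fold lower number from compound 2 to compound 1 (0.73 log units; beyond the scatter), starts from a limit, so its full size is unknown. The step expected here is a 3.3-fold lower number from compound 3 to compound 4 (0.52 log units; beyond the scatter). Compound 4 is therefore expected to give about 10000 nM, between 4000 nM and 30000 nM.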

Compound 4, half-maximal inhibitory concentration: 10500 nM
Compound 4: the middle estimate sits 1.1-fold (0.02 log units) below what was measured, and the stated range covers the measured number.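

Hydrogen in place of methyl gives a 3.1-fold lower number from compound 3 to compound 4 (0.50 log units; beyond the scatter) in this assay, so the change points the same way on the chloro compounds as on the fluoro compounds, though its size may or may not match: the same change on two cores in this assay, an at least 5.4-fold lower number (0.73 log units; beyond the scatter) from compound 2 to compound 1 and a 3.1-fold lower number (0.50 log units; beyond the scatter) from compound 3 to compound 4; the limit leaves it open whether they differ

Chloro in place of fluoro gives a 1.7-fold lower number from compound 1 to compound 4 (0.24 log units; within the scatter), so without the methyl this change does not clear the usual scatter, yet no difference between the two cores can be claimed: the same change on two cores in this assay, an at least 3.0-fold lower number (0.48 log units; beyond the scatter) from compound 2 to compound 3 and a 1.7-fold lower number (0.24 log units; within the scatter) from compound 1 to compound 4; the limit leaves it open whether they differ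

Compound 2 stands at > 100000 nM, which is a limit and not a number, so these compounds show the direction of the methyl step but not its full size on the fluoro compounds.

As far as these compounds go, only hydrogen and methyl appear at the one varied place, and only fluoro and chloro at the other, so it remains open how an ethyl group, a methoxy group or an amine would behave in place of the methyl, or bromo in place of the chloro. From the compounds shown here alone, it also remains open whether these steps would hold in other cell lines.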